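Alkoxy chain extension on the aryl ring of compound 2

The source may report more compounds than this note shows. Statements on the series, on what has been measured and on what is new or still open speak of the compounds shown alone.

Compound 2 `CCOc1cc(-c2cc3c(O)nc(C)nc3cc2C(C)C)ccc1Cl` is the reference point of this small set. In a functional assay for inhibition of transient receptor potential cation channel subfamily V member 1 (Homo sapiens), read by fluorescence and calcium flux (a lower number here means a stronger inhibitor, a higher number a weaker inhibitor), compound 2 gives 12 nM, the lowest of the three numbers. Compound 1 `COc1cc(Cl)cc(-c2cc3c(O)nc(C)nc3cc2C(C)C)c1` gives 100 nM in this assay, and compound 3 `CCOc1cc(-c2cc3c(O)nc(C)nc3cc2C(C)C)ccc1OC` gives 286 nM. Compound 1 differs from compound 2 in more than one place, so only its value stands beside that of compound 2. Among the measured compounds shown here, the one single-point step that is known, a 24-fold higher number from compound 2 to compound 3 (1.38 log units; beyond the scatter), involves the substituent bound directly to the aromatic ring and not the alkoxy chain.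

Compound 4 `Cc1nc(O)c2cc(-c3ccc(Cl)c(OCC4CCC4)c3)c(C(C)C)cc2n1` differs from compound 2 by cyclobutyl in place of methyl on a saturated chain carbon bound to an oxygen on an aromatic ring. For the measured compounds named here, no measured pair addresses a change of this kind: the chloro substituent of compound 2 is kept, and only the chain on the aromatic oxygen grows. The step from compound 2 to compound 3 therefore does not transfer to this change, and no other single-point comparison exists. With nothing in the data pointing toward a large shift in either direction, the expectation for compound 4 in this assay is a number close to that of compound 2, a 1.3-fold higher number from compound 2 to compound 4 (0.10 log units; within the scatter), within the scatter or only slightly beyond it.

Compound 4 is estimated at 15 nM in this assay, with a range from 5 nM to 60 nM.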

Compound 4, half-maximal inhibitory concentration: 144 nM
The estimate for compound 4 lay 9.6-fold (0.98 log units) below the measured number, outside the stated range (above it).
By their numbers in this assay, from the lowest: compound 2; then compounds 1, 4 and 3 (each within the scatter of the next, the first and the last beyond it).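

Working notes: the chain on the aromatic oxygen is not a neutral position in this series. With the chloro substituent kept, the change from ethoxy to cyclobutylmethoxy in this assay gives a 12-fold higher number from compound 2 to compound 4 (1.08 log units; beyond the scatter). Two places on the aryl ring now each carry a single-point step beyond the scatter, this one and a 24-fold higher number from compound 2 to compound 3 (1.38 log units; beyond the scatter), and both changes away from compound 2 lead to a higher number. The data at hand offer no explanation for the step at the oxygen chain.

Among the compounds shown here, the single step does not separate the effect of the longer chain from that of the four-membered ring, and a straight propoxy or butoxy chain, or a cyclopropylmethoxy group, on the same oxygen with the chloro substituent kept would bear directly on that question. Also open, from the compounds shown here alone, are how an amine or a carboxylic acid at the end of the chain would read in this assay, and whether the cyclobutylmethoxy change would give a similar step with methoxy in place of chloro on the aromatic carbon.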